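Acylurea Thiazole Hydrazones: Anticipating a Nitrophenyl Analogue

The source may report more compounds than this note shows. Statements on the series, on what has been measured and on what is new or still open speak of the compounds shown alone.

Measured compounds:
compound 1 `CN(C(=O)NC(=O)c1ccc(Cl)cc1Cl)c1nc(C(F)(F)F)c(C(=O)N/N=C/c2cccc(C(F)(F)F)c2)s1` — 6.11 ug/mL
compound 2 `CN(C(=O)NC(=O)c1ccc(C(F)(F)F)cc1)c1nc(C(F)(F)F)c(C(=O)N/N=C/c2cccc(C(F)(F)F)c2)s1` — 1.84 ug/mL
compound 3 `CN(C(=O)NC(=O)c1ccc(F)c(F)c1)c1nc(C(F)(F)F)c(C(=O)N/N=C/c2cccc(C(F)(F)F)c2)s1` — 4.46 ug/mL

In a functional assay on BCG823 cells (Homo sapiens) for inhibition, read by MTT assay, with a stated time of 72 h (on this read-out higher numbers stand for weaker inhibition and lower numbers for stronger inhibition), compound 3 gives 4.46 ug/mL, the second highest of the three numbers; the gap to compound 1 is within the scatter, while a 2.4-fold higher number from compound 2 to compound 3 (0.38 log units; beyond the scatter). Compound 4 `CN(C(=O)NC(=O)c1ccc([N+](=O)[O-])cc1)c1nc(C(F)(F)F)c(C(=O)N/N=C/c2cccc(C(F)(F)F)c2)s1` differs from compound 3 in one place: 4-nitrophenyl in place of 3,4-difluorophenyl on a carbonyl carbon. For the measured compounds named here, no measured step covers this exact exchange. The steps at the same carbonyl carbon were a 3.3-fold lower number from compound 1 to compound 2 (0.52 log units; beyond the scatter), a 1.4-fold lower number from compound 1 to compound 3 (0.14 log units; within the scatter) and a 2.4-fold higher number from compound 2 to compound 3 (0.38 log units; beyond the scatter), so changes there have moved the number only modestly. For compound 4 a small step is therefore expected, a 1.4-fold lower number from compound 3 to compound 4 (0.14 log units; within the scatter), with direction uncertain. The estimate for compound 4 is 3.2 ug/mL, expected to lie between 1.2 ug/mL and 8.5 ug/mL.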

Compound 4, half-maximal inhibitory concentration: 1.67 ug/mL
Estimate against measurement, compound 4: 1.9-fold (0.28 log units) above, within the range that was stated.
By their numbers in this assay, from the lowest: compounds 4 and 2 (each within the scatter of the next); then compounds 3 and 1 (each within the scatter of the next).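

In this assay the 4-nitrophenyl group on the carbonyl carbon gives a 2.7-fold lower number from compound 3 to compound 4 (0.43 log units; beyond the scatter) and a 3.7-fold lower number from compound 1 to compound 4 (0.56 log units; beyond the scatter), so it separates from both the 3,4-difluorophenyl and the 2,4-dichlorophenyl groups. Nitro in place of trifluoromethyl on the aromatic carbon gives a 1.1-fold lower number from compound 2 to compound 4 (0.04 log units; within the scatter), so compounds 2 and 4 cannot be told apart, and two different groups there share the lower numbers. No evidence is at hand to explain this. On these data alone, whether an amine or a nitrile in place of the nitro group would also keep the number this low remains open.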